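The compounds below may be only part of what the source reports. "The series", "measured", "known", "first", "only" and "open" are said of these compounds alone.

The measured compounds in this series:

compound 1, `O=S(=O)(NNc1ccc(Br)cc1)c1ccc(Br)cc1`, 85 nM
compound 2, `N#Cc1ccc(S(=O)(=O)NNc2ccc(Br)cc2)cc1`, 176 nM
compound 3, `O=C(O)CCc1ccc(S(=O)(=O)NNc2ccc(Br)cc2)cc1`, 141 nM

All three were tested in an assay for inhibition of Indoleamine 2,3-dioxygenase 1 (Homo sapiens), read by spectrophotometry, with stated times of 1 h and 4 h (a lower number here means a stronger inhibitor, a higher number a weaker inhibitor), and they differ only in the group carried on one aromatic carbon of the shared core. Compound 3 sits with its number between the other two, but the two steps that reach it, a 1.7-fold higher number from compound 1 to compound 3 (0.22 log units; within the scatter) and a 1.2-fold lower number from compound 2 to compound 3 (0.10 log units; within the scatter), both fall within the scatter, so no order among these three can be read from the numbers. For the measured compounds named here, the only step beyond the scatter is a 2.1-fold higher number from compound 1 to compound 2 (0.32 log units; beyond the scatter), and even that is modest.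

Compound 4, `O=C(O)c1ccc(S(=O)(=O)NNc2ccc(Br)cc2)cc1`, differs from compound 3 by carboxy in place of 2-carboxyethyl on an aromatic carbon. The acid group stays; only the chain that holds it away from the ring is removed. All three measured steps changed the group at this same position, and none of them moved the number far. Going by the values given here, no measured pair shows a carboxy placed directly on the ring, so the comparison is indirect. Compound 4 is therefore expected to land close to compound 3, with a 1.1-fold higher number from compound 3 to compound 4 (0.03 log units; within the scatter), no step beyond the scatter. The estimate for compound 4 is 150 nM, with a range from 60 nM to 400 nM.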

Compound 4, half-maximal inhibitory concentration: 61 nM
For compound 4 the middle estimate is 2.5-fold (0.39 log units) above the measured one; the range from low to high includes it.
By their numbers in this assay, from the lowest: compounds 4, 1, 3 and 2 (each within the scatter of the next, the first and the last beyond it).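

In this assay, for the compounds shown here, the acid group stays in place, yet the chain that holds it still counts: a 2.3-fold lower number from compound 3 to compound 4 (0.36 log units; beyond the scatter) is modest but beyond the scatter, and it is the first step that keeps the acid and changes only what links it to the ring. Carboxy can also be told apart from nitrile at this position, with a 2.9-fold lower number from compound 2 to compound 4 (0.46 log units; beyond the scatter) likewise modest and beyond the scatter, whereas a 1.4-fold lower number from compound 1 to compound 4 (0.14 log units; within the scatter) lies within the scatter and leaves carboxy and bromo unseparated. Nothing available here explains these differences.

The compounds shown leave open where carboxymethyl, a chain of intermediate length carrying the same acid, would fall relative to carboxy and 2-carboxyethyl, and whether an amine or a primary amide at this place would give numbers like those of carboxy. They also leave open whether the step from 2-carboxyethyl to carboxy would hold with another group in place of the bromo that all four compounds share on the far end of the shared core.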